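Benzothiazole-imine series, whole-animal dosing: dimethylsulfamoyl to methylamino

The compounds below may be only part of what the source reports. "The series", "measured", "known", "first", "only" and "open" are said of these compounds alone.

Measured so far in a functional assay on the whole organism with Rattus norvegicus as the target; on this read-out higher numbers stand for an effect only at larger amounts of compound and lower numbers for an effect already at smaller amounts:
compound 1 `CCC(C)(C)c1ccc2nc(N)sc2c1` — > 10 mg/kg, a limit of the assay
compound 2 `CCCCCCCc1ccc2nc(N)sc2c1` — > 10 mg/kg, a limit of the assay
compound 3 `CN(C)S(=O)(=O)CCn1c(=N)sc2cc(OC(F)(F)F)ccc21` — > 10 mg/kg, a limit of the assay

Among the measured compounds shown here, every value so far is a limit: the limit of > 10 mg/kg in this assay, at which 3 of the 3 values shown sit. For the measured compounds named here, compound 3 therefore stands nowhere that can be placed against the others; it shares the limit with them, and no step between measured compounds is available.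

Compound 4 `CNCCn1c(=N)sc2cc(OC(F)(F)F)ccc21` is not yet measured. It differs from compound 3 as follows: methylamino in place of dimethylsulfamoyl on a saturated chain carbon, two bonds along the chain from an aromatic nitrogen. Going by the values given here, no measured pair shows what such a change does here, so no direction beyond the scatter can be expected for a number no higher from compound 3 to compound 4 (the limit leaves the size open) on the evidence at hand. For compound 4 the estimate in this assay is 10 mg/kg, with a range from 3 mg/kg to 30 mg/kg, and a limit remains the likelier outcome.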

Compound 4, dose for half-maximal effect: > 10 mg/kg
Compound 4 gave a limit, no number; the forecaster's own chance of this, stated with the estimate: 60%; the middle value sits exactly at the limit.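

No step can be read between compound 3 and compound 4, since both values are limits: the limit of > 10 mg/kg in this assay, at which 4 of the 4 values shown sit.

Still open is what methylamino in place of dimethylsulfamoyl does to the dose needed, and where any compound shown would give a numerical value.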